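This account rests on a few compounds, and the source may have more. Where it says the series, first, only, none or still open, it means among the compounds named here.

Compound 1 `CCc1nnc(SCC(=O)c2ccccc2)n1N1C(=O)c2ccccc2C1=O` gives in a functional assay on MKN-45 cells (Homo sapiens) for cytotoxicity, read by MTT assay, with a stated time of 48 h; a higher number here means a weaker inhibitor, a lower number a stronger inhibitor > 200000 nM, which is a limit of the assay and not a number.
Compound 2 `CCCc1nnc(SCC(=O)c2ccc(Cl)cc2)n1N1C(=O)c2ccccc2C1=O` gives in this assay > 200000 nM, also a limit.
Compound 3 `C#CCSc1nnc(CCC)n1N1C(=O)c2ccccc2C1=O` gives in this assay > 200000 nM, again a limit.

Compound 3 therefore stands on no number at all: every value shown sits at the same limit (the limit of > 200000 nM in this assay, at which 3 of the 3 values shown sit). Compound 4 `CCCc1nnc(SCC(=O)c2ccccc2)n1N1C(=O)c2ccccc2C1=O` differs from compound 3 in one place: benzoyl in place of ethynyl on a saturated chain carbon bound to a sulfur. Within the data shown here, the one measured step at this position, a step that the two limits leave unreadable from compound 2 to compound 3, runs between two limits and so gives neither size nor direction. With nothing readable to build on, the expected step is a step that the limit leaves unreadable from compound 3 to compound 4, nothing beyond the scatter. Compound 4 is estimated at 300000 nM, with a range from 100000 nM to 1000000 nM, and will most likely be reported only as a limit once more.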

Compound 4, half-maximal inhibitory concentration: > 200000 nM
Compound 4 ended at the assay's limit; the forecaster's own chance of this, stated with the estimate: 85%; the middle value is on the limit's open side.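

Compound 4 sits at the same limit as compound 1, compound 2 and compound 3, so no step among these compounds can be read: the limit of > 200000 nM in this assay, at which 4 of the 4 values shown sit.

Going by these compounds, whether any change to the shared core would give a real number in this assay stays open.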